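From 2,5-dimethylphenyl to 3-chlorophenyl on the sulfonamide

A few compounds are considered here, and "the series" means these few. Any claim that something is new, unique, unknown or untested is made for them only; others in the source may bear on it.

In a functional assay on K562 cells (Homo sapiens) for antiproliferative activity, read by sulforhodamine B assay, with a stated time of 48 h (on this read-out higher numbers stand for weaker inhibition and lower numbers for stronger inhibition), compound 1 (`Cc1cccc(NS(=O)(=O)c2ccc(N3CCNC3=O)cc2)c1`) gives 200 nM and compound 2 (`Cc1ccc(C)c(NS(=O)(=O)c2ccc(N3CCNC3=O)cc2)c1`) gives 72 nM, the lower of the two numbers. Among the compounds with values here, the only measured step, a 2.8-fold lower number from compound 1 to compound 2 (0.44 log units; beyond the scatter), lies beyond the scatter and comes from methyl in place of hydrogen on an aromatic carbon. Compound 3 (`O=C1NCCN1c1ccc(S(=O)(=O)Nc2cccc(Cl)c2)cc1`) has 3-chlorophenyl in place of 2,5-dimethylphenyl on a sulfonamide nitrogen. Within the data shown here, no measured step exchanges methyl for chlorine, so the evidence is thin. Compound 3 has no second group on that ring, and neither has compound 1 at 200 nM. A modest rise in this assay is therefore expected, close in size to the measured step but opposite in direction: a 2.4-fold higher number from compound 2 to compound 3 (0.37 log units; beyond the scatter) is the expected step. For compound 3 the estimated value is 170 nM, with an expected range of 60 nM to 480 nM.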

Compound 3, half-maximal inhibitory concentration: 69 nM
Beside the measured number, compound 3's estimate is 2.5-fold (0.39 log units) above it; the measured number falls inside the stated range.
By their numbers in this assay, from the lowest: compounds 3 and 2 (each within the scatter of the next); then compound 1.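

In this assay, 3-chlorophenyl in place of 2,5-dimethylphenyl on a sulfonamide nitrogen gives a 1.0-fold lower number from compound 2 to compound 3 (0.02 log units; within the scatter) and so leaves the number unchanged within the scatter, which shows that a ring carrying one group can match the ring carrying two. Compound 1 also carries a single group and goes against any simple need for a second one, since chloro in place of methyl on an aromatic carbon gives a 2.9-fold lower number from compound 1 to compound 3 (0.46 log units; beyond the scatter), a step close in size to the one that the added methyl gave earlier. Nothing shown here explains why these two different changes arrive at the same level.

As far as these compounds go, it remains open whether 2,5-dichlorophenyl would bring the number lower still than either group alone. The compounds also leave open how a methoxy group or a carboxylic acid on that ring would compare with chloro and methyl.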